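Notes on compound 2 and its trifluoromethoxy analogue

This account rests on a few compounds, and the source may have more. Where it says the series, first, only, none or still open, it means among the compounds named here.

Compound 1 `Cc1cc(=O)oc2cc(SCc3cccnc3)ccc12` and compound 2 `Cc1cc(=O)oc2cc(SCc3cccc(C#N)c3)ccc12` share one core and differ only in the group carried on the pendant aromatic ring. In a functional assay on KB cells (Homo sapiens) for antiproliferative activity, read by sulforhodamine B assay, with a stated time of 72 h (on this read-out higher numbers stand for weaker inhibition of growth and lower numbers for stronger inhibition of growth), compound 1 gives > 35200 nM, which is a limit of the assay and not a number. In this assay compound 2 gives > 32500 nM, likewise a limit rather than a measured number. Both values shown therefore sit at limits (the limit of > 32500 nM in this assay, at which 1 of the 2 values shown sits, and (the limit of > 35200 nM in this assay, at which 1 of the 2 values shown sits)), so compound 2 stands with compound 1 as unresolved by the assay, with no number that would set the two apart.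

Compound 3 `Cc1cc(=O)oc2cc(SCc3cccc(OC(F)(F)F)c3)ccc12` is the next member of the series: trifluoromethoxy in place of cyano on an aromatic carbon. For the measured compounds named here, no measured step of this kind exists, so the size of the change in this assay cannot be read from the data; the expectation is for no movement beyond the scatter, with the read-out again most likely reported only as a limit. Compound 3 is expected at 40000 nM, within 15000 nM to 110000 nM, which means an expected step that the limit leaves unreadable from compound 2 to compound 3.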

Compound 3, concentration for 50% growth inhibition: 14800 nM
Compound 3: the middle estimate sits 2.7-fold (0.43 log units) above what was measured, outside the stated range (below it).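

In this assay, trifluoromethoxy in place of cyano on an aromatic carbon, meta to a large group, gives an at least 2.1-fold lower number from compound 2 to compound 3 (0.34 log units; beyond the scatter). For the compounds shown here, of the three values shown, only the one for the trifluoromethoxy compound is a number and not a limit, so this position does respond to a change of group, which the earlier pair could not show. The true size of the step stays unknown, and the printed figure is only its lower bound, because compound 2 sits at a limit: the limit of > 32500 nM in this assay, at which 1 of the 3 values shown sits.

Still open, going by these compounds, is which part of the trifluoromethoxy group carries the step, and a methoxy group or a trifluoromethyl group on the same aromatic carbon would separate the oxygen link from the fluorine atoms. Also open, on these data alone, is whether the series can move further from this single numerical value, for instance with an amine or a carboxylic acid at this position, or with trifluoromethoxy placed elsewhere on the pendant ring.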